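Series notes: alkynyl pyrimidine isomer swap on compound 2

This account rests on a few compounds, and the source may have more. Where it says the series, first, only, none or still open, it means among the compounds named here.

Compound 1 `C#Cc1ccc2ncn(-c3ccnc(N)n3)c2c1` gives 251 nM in an assay on Sf9 cells for inhibition of mitogen-activated protein kinase kinase kinase 14 variant S549D (Homo sapiens), with a stated time of 30 min, in the presence of a further agent that is not named here; a higher number here means a weaker inhibitor, a lower number a stronger inhibitor. Among the measured compounds shown here, compound 2 `C#Cc1nccc(C#Cc2ccc3ncn(-c4ccnc(N)n4)c3c2)n1` carries a further ring on the terminal alkyne and gives 39800 nM; this is the highest number of the two measured, and the single measured step, a 160-fold higher number from compound 1 to compound 2 (2.20 log units; beyond the scatter), is large. Compound 3 `C#Cc1cc(C#Cc2ccc3ncn(-c4ccnc(N)n4)c3c2)ncn1` is the next entry. The change is a group of 8 heavy atoms (6 carbon, 2 nitrogen; one six-membered aromatic ring with 2 hetero atoms) in place of a group of 8 heavy atoms (6 carbon, 2 nitrogen; one six-membered aromatic ring with 2 hetero atoms), on a triple-bonded carbon: the same atoms, joined differently, so nothing is added or removed, only the way the second ring is attached and its ring nitrogens placed differs. For the measured compounds named here, no measured step bears directly on such a rearrangement; the only step in hand shows the cost of introducing this group at all, not of moving within it. Compound 2 and compound 3 therefore share the feature that separates them from compound 1, and the expectation is a step of a 1.3-fold lower number from compound 2 to compound 3 (0.12 log units; within the scatter), in either direction, not clearly beyond the scatter. On that basis compound 3 is estimated at 30000 nM, with a range from 8000 nM to 120000 nM, pending the actual value.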

Compound 3, half-maximal inhibitory concentration: 50100 nM
Beside the measured number, compound 3's estimate is 1.7-fold (0.22 log units) below it; low and high end bracket the measured number.
By their numbers in this assay, from the lowest: compound 1; then compounds 2 and 3 (each within the scatter of the next).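

In this assay, rearranging the group on the triple-bonded carbon gives a 1.3-fold higher number from compound 2 to compound 3 (0.10 log units; within the scatter), so the two arrangements of these same atoms cannot be told apart. Compound 3 also shows a 200-fold higher number from compound 1 to compound 3 (2.30 log units; beyond the scatter), and the large loss seen with compound 2 therefore recurs with a second arrangement of the ring nitrogens and the outer triple bond, which means it is not tied to one arrangement alone. No evidence is at hand on why this group costs so much at this position.

Still open, going by these compounds, is whether the loss belongs to the six-membered aromatic ring with 2 hetero atoms or to the triple bond it carries, since the two always occur together in compound 2 and compound 3. On these data alone, it is equally open whether a much smaller group on the triple-bonded carbon, such as methyl, hydroxymethyl or a short aminomethyl chain, would stay close to compound 1 or would also give a large step.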